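The compounds below may be only part of what the source reports. "The series", "measured", "known", "first", "only" and "open" are said of these compounds alone.

Measured so far in a functional assay on P388 cells (Mus musculus); a higher number here means a weaker inhibitor, a lower number a stronger inhibitor:
- Compound 1 `COc1ccc(/C=C/C(=O)Oc2ccc(/C=C3\CCCC(CN(C)C)C3=O)cc2)cc1` gives 2410 nM
- Compound 2 `O=C1CCCC/C1=C\c1ccc(OC(=O)c2ccccc2)cc1` gives > 50000 nM (a limit)

Compound 2 gives no number, and its > 50000 nM is a limit of the assay. Compound 3 `CN(C)CC1CCC/C(=C\c2ccc(OC(=O)c3ccccc3)cc2)C1=O` carries one change from it, ((dimethylamino)methyl in place of hydrogen on a saturated ring carbon), with (dimethylamino)methyl in place of hydrogen on a saturated ring carbon. Among the measured compounds shown here, no measured step isolates this change. Compound 1 also bears (dimethylamino)methyl and gives 2410 nM in this assay, which is the only basis for the expectation here. A large step towards stronger inhibition is expected, estimated as an at least 12-fold lower number from compound 2 to compound 3 (1.09 log units; beyond the scatter) here. Compound 3 is expected near 4000 nM, within an estimated range of 1000 nM to 20000 nM overall.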

Compound 3, half-maximal inhibitory concentration: 180 nM
Beside the measured number, compound 3's estimate is 22-fold (1.35 log units) above it; measured number outside the range, below it.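

In this assay compound 2 gives only a limit, > 50000 nM. From the compounds shown here alone, the step that adds the (dimethylamino)methyl group now has a direct reading, an at least 270-fold lower number from compound 2 to compound 3 (2.44 log units; beyond the scatter), so the gain on this ring carbon is large, though its full size stays unknown. With that group held, phenyl in place of 2-(4-methoxyphenyl)ethenyl on a carbonyl carbon gives a 13-fold lower number from compound 1 to compound 3 (1.13 log units; beyond the scatter), so the benzoate form is the stronger of the pair.

Open, going by these compounds, is whether a pyrrolidine or morpholine in place of the dimethylamino group holds this level. A longer chain between the amine and the ring is equally untested in these compounds.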